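The source may hold more compounds than are shown below. What is called first, only, known or untested is meant among the compounds shown, and "the series" means these compounds.

Compound 2 `N#C[Se]c1ccc(NC(=O)OCc2ccc([N+](=O)[O-])cc2)cc1` carries a selenocyanate group on one ring and a carbamate that links to a second ring bearing a nitro group. Going by the values given here, in a functional assay on MCF7 cells (Homo sapiens) for cytotoxicity, read by MTT assay, with a stated time of 72 h (a lower number here means a stronger inhibitor of growth, a higher number a weaker inhibitor of growth), compound 2 gives 11800 nM, the lowest of the two numbers measured so far. Its nearest neighbour is compound 1 `CC(C)COC(=O)Nc1ccc([Se]C#N)cc1`, which in this assay gives 18100 nM; the two values lie within the scatter of each other, so neither can be called the stronger.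

Compound 3 `N#C[Se]c1ccc(NC(=O)OCc2ccccc2)cc1` differs from compound 2 in a single place: hydrogen in place of nitro on an aromatic carbon. Among the compounds with values here, no pair of measured compounds shows this change, so no measured step is at hand to guide the expectation. The change removes a small group far from the selenocyanate, and the step from compound 2 to compound 3 is expected to be modest, likely no larger than the scatter, in either direction, at a 1.2-fold higher number from compound 2 to compound 3 (0.07 log units; within the scatter). For compound 3 the expected value in this assay is 14000 nM, with a range from 6000 nM to 35000 nM.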

Compound 3, concentration for 50% growth inhibition: 8700 nM
The estimate for compound 3 lay 1.6-fold (0.21 log units) above the measured number; the range from low to high includes it.
By their numbers in this assay, from the lowest: compounds 3, 2 and 1 (each within the scatter of the next, the first and the last beyond it).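

In this assay, hydrogen in place of nitro on an aromatic carbon gives a 1.4-fold lower number from compound 2 to compound 3 (0.13 log units; within the scatter), so at this position, para to a large group, losing the nitro group leaves the growth inhibition indistinguishable from that of compound 2. Phenyl in place of isopropyl on a saturated chain carbon bound to an oxygen next to a carbonyl group gives a 2.1-fold lower number from compound 1 to compound 3 (0.32 log units; beyond the scatter), a modest step but the only one here beyond the scatter, which shows that the group at this end of the carbamate can shift the number. No measurement here explains either step.

As far as these compounds go, whether an amine or a methoxy group at the nitro position would behave like hydrogen remains open. So does whether a longer chain or a cyclohexyl group in place of the phenyl would match compound 3.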